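The compounds below may be only part of what the source reports. "The series", "measured", "known", "first", "only" and "open" are said of these compounds alone.

Measured compounds:
compound 1, `CC(C)(O)Cn1nc(-c2cc(C3CC3)on2)c2c(N)ncnc21`: 6750 nM
compound 2, `CCCCCCCn1nc(-c2cc(C3CC3)on2)c2c(N)ncnc21`: > 10000 nM

Both compounds share one core and differ only in the group on the aromatic nitrogen. In an assay on BaF3 cells for inhibition of proto-oncogene tyrosine-protein kinase receptor Ret variant V804M (Homo sapiens), read by MTT assay, with a stated time of 48 h (on this read-out lower numbers stand for stronger inhibition of growth and higher numbers for weaker inhibition of growth), compound 1 gives 6750 nM. For compound 2 this assay reports only a limit, > 10000 nM, so compound 2 sits at the limit of > 10000 nM in this assay, at which 1 of the 2 values shown sits, and its true number is not known. Going by the values given here, the single measured step, an at least 1.4-fold higher number from compound 1 to compound 2 (0.17 log units; that floor lies within the scatter), therefore only sets a floor.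

Compound 3, `Nc1ncnc2c1c(-c1cc(C3CC3)on1)nn2C1CCOCC1`, differs from compound 2 by oxan-4-yl in place of heptyl on an aromatic nitrogen. The step from compound 1 to compound 2 is the only one that bears on this change, and it is small and capped by a limit. The oxan-4-yl group brings a six-membered ring with one hetero atom and one hydrogen-bond acceptor in place of the plain heptyl chain, which brings compound 3 closer in kind to compound 1 than to compound 2. Compound 3 is therefore expected to give about 5000 nM in this assay, within 1500 nM to 15000 nM. This expectation corresponds to an estimated step of an at least 2.0-fold lower number from compound 2 to compound 3 (0.30 log units; that floor lies within the scatter).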

Compound 3, concentration for 50% growth inhibition: 1930 nM
Compound 3: the middle estimate sits 2.6-fold (0.41 log units) above what was measured, and the stated range covers the measured number.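

In this assay, changing the group on the aromatic nitrogen now gives steps beyond the scatter, which the earlier step could not show: an at least 5.1-fold lower number from compound 2 to compound 3 (0.71 log units; beyond the scatter), and a 3.5-fold lower number from compound 1 to compound 3 (0.54 log units; beyond the scatter). Compound 3, with oxan-4-yl, therefore has the lowest number of the three, and a ring at this position outdoes both open chains shown, one with a hydroxyl group and one without. Compound 2 carries only a limit, so the first of these steps sets a floor and its full size stays unknown: the limit of > 10000 nM in this assay, at which 1 of the 3 values shown sits.

The compounds shown do not tell whether the ring oxygen of oxan-4-yl matters, or whether the ring alone is enough, as an all-carbon cyclohexyl group would test. They also leave open how a ring bearing an amine, such as piperidin-4-yl, would read at this position.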